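A few compounds are considered here, and "the series" means these few. Any claim that something is new, unique, unknown or untested is made for them only; others in the source may bear on it.

Measured so far:
- Compound 1 `O=C(/C=C/c1cn(S(=O)(=O)c2cccc([N+](=O)[O-])c2)c2ccccc12)c1ccncc1`: 36300 nM
- Compound 2 `CCCS(=O)(=O)n1cc(/C=C/C(=O)c2ccncc2)c2ccccc21`: 52400 nM

In a functional assay on MCF7 cells (Homo sapiens) for antiproliferative activity, read by MTT assay, with a stated time of 48 h (a lower number here means a stronger inhibitor, a higher number a weaker inhibitor), compound 2 gives 52400 nM, a value within the scatter of compound 1, so the two cannot be told apart. The next compound is compound 3 `O=C(/C=C/c1cn(S(=O)(=O)c2ccccc2[N+](=O)[O-])c2ccccc12)c1ccncc1`, with 2-nitrophenyl in place of propyl on a sulfonyl sulfur. Within the data shown here, only one measured step bears on this change, a 1.4-fold higher number from compound 1 to compound 2 (0.16 log units; within the scatter), which put propyl in place of 3-nitrophenyl at the same place and stayed within the scatter. Among the measured compounds shown here, no compound with 2-nitrophenyl has been measured yet, so that step is only an indirect guide. On the evidence of that step, no change beyond the scatter is expected in this assay. The expected step is a 1.3-fold lower number from compound 2 to compound 3 (0.12 log units; within the scatter), which is an estimate. For compound 3 the estimated value is 40000 nM, with an expected range from 17000 nM to 95000 nM.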

Compound 3, half-maximal inhibitory concentration: 36900 nM
Beside the measured number, compound 3's estimate is 1.1-fold (0.04 log units) above it; the range from low to high includes it.
By their numbers in this assay, from the lowest: compounds 1, 3 and 2 (each within the scatter of the next).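

In this assay, the new result adds a second kind of change on the sulfonyl sulfur, and neither step leaves the scatter: putting 2-nitrophenyl in place of propyl gives a 1.4-fold lower number from compound 2 to compound 3 (0.15 log units; within the scatter), and putting 2-nitrophenyl in place of 3-nitrophenyl gives a 1.0-fold higher number from compound 1 to compound 3 (0.01 log units; within the scatter). Propyl, 3-nitrophenyl and 2-nitrophenyl therefore cannot be told apart at this place in this assay, whether the group is an aromatic ring or a short chain, and whichever of the two nitrophenyl groups is present. Nothing measured here offers an explanation for this result.

As far as these compounds go, it remains open whether an amine, a carboxylic acid or a longer chain on the sulfonyl sulfur would give a step beyond the scatter. From the compounds shown here alone, all three compounds also share the same core, so the effect of a change elsewhere in it remains unknown.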